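Swapping bromo for fluoro in a cell toxicity test

This account rests on a few compounds, and the source may have more. Where it says the series, first, only, none or still open, it means among the compounds named here.

Within the data shown here, in a functional assay on HGC cells (Homo sapiens) for cytotoxicity, read by MTT assay, with a stated time of 48 h (on this read-out higher numbers stand for weaker inhibition and lower numbers for stronger inhibition), compound 1 `CC(C)n1c(/C=C2/C(=O)Nc3ccc(F)cc32)nc2ccccc21` gives 28000 nM, the only true number in this small set. For compound 2 `Cn1c(/C=C2/C(=O)Nc3ccc([N+](=O)[O-])cc32)nc2ccccc21` the entry reads "not determined" (no result reported), so it offers nothing to compare. Compound 3 `Cn1c(/C=C2/C(=O)Nc3ccc(Br)cc32)nc2ccccc21` reads > 50000 nM, which is a limit and not a number. On the numbers shown, then, compound 3 has no exact position, and all that can be said is where the limit lies.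

The next molecule, compound 4 `Cn1c(/C=C2/C(=O)Nc3ccc(F)cc32)nc2ccccc21`, departs from compound 3 at one place: fluoro in place of bromo on an aromatic carbon. In plain terms, that is the whole difference, and nothing else changes.

Among the measured compounds shown here, no pair of measured compounds shows what a single change does in this assay, so any expectation here is loose. It leans on compound 1, which gives 28000 nM and shows that a measurable result can appear within this small set. The estimated move is an at least 1.2-fold lower number from compound 3 to compound 4 (0.09 log units; that floor lies within the scatter), a small one toward stronger inhibition, and it may not exceed the usual scatter. For compound 4 the expected value is 40000 nM, with an estimated range from 18000 nM to 70000 nM.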

Compound 4, half-maximal inhibitory concentration: 37800 nM
The estimate for compound 4 lay 1.1-fold (0.02 log units) above the measured number; the measured number falls inside the stated range.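

In this assay, fluoro in place of bromo on an aromatic carbon gives an at least 1.3-fold lower number from compound 3 to compound 4 (0.12 log units; that floor lies within the scatter). Among these compounds, this is the first readable step at this position, but it is only a floor and does not clear the usual scatter, so it does not show that fluoro truly improves on bromo. The real size of the step stays unknown because compound 3 carries a limit and not an exact number: the limit of > 50000 nM in this assay, at which 1 of the 4 values shown sits.

The second step keeps fluoro fixed and changes the group on the aromatic nitrogen, with methyl in place of isopropyl giving a 1.4-fold higher number from compound 1 to compound 4 (0.13 log units; within the scatter), so these two groups cannot be told apart in this test.

The compounds shown leave open what an amine or a carboxylic acid on this aromatic carbon would do, and whether a longer chain on the aromatic nitrogen would move the number beyond the scatter. Compound 2 has no reported result, so it gives no further help on this position.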